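Swapping a pyrazole for a pyrimidine on the urea side chain

A few compounds are considered here, and "the series" means these few. Any claim that something is new, unique, unknown or untested is made for them only; others in the source may bear on it.

Measured so far:
compound 1 `CCOC(=O)c1ccc(NC(=O)NCc2cocn2)cc1`: 27600 nM
compound 2 `CCOC(=O)c1ccc(NC(=O)NCc2cc[nH]n2)cc1`: 69000 nM
compound 3 `CCOC(=O)c1ccc(NC(=O)NCc2cn[nH]c2)cc1`: 1850 nM

All three share one core and differ only in the small aromatic ring attached to the saturated chain carbon bound to the amide-type nitrogen. In an assay on isolated protein for activation of Nicotinamide phosphoribosyltransferase (Homo sapiens) (a lower number here means that less compound is needed, a higher number that more compound is needed for the effect), compound 3 gives the lowest number of the three: a 15-fold lower number from compound 1 to compound 3 (1.17 log units; beyond the scatter) and a 37-fold lower number from compound 2 to compound 3 (1.57 log units; beyond the scatter), both large. Compound 4 `CCOC(=O)c1ccc(NC(=O)NCc2ccncn2)cc1` has not yet been measured in this assay. Its change from compound 3 is pyrimidin-4-yl in place of 1H-pyrazol-4-yl on a saturated chain carbon bound to an amide-type nitrogen. Going by the values given here, no measured step covers a six-membered ring in this place, so the nearest guide is the step from a ring without a hydrogen-bond donor to compound 3, a 15-fold lower number from compound 1 to compound 3 (1.17 log units; beyond the scatter); compound 4 likewise carries no donor. On that basis the number for compound 4 is expected to rise clearly, an estimated step of an 11-fold higher number from compound 3 to compound 4 (1.03 log units; beyond the scatter). The estimate for compound 4 in this assay is therefore 20000 nM, with a plausible range from 4000 nM to 100000 nM.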

Compound 4, half-maximal effective concentration: 13600 nM
Beside the measured number, compound 4's estimate is 1.5-fold (0.17 log units) above it; low and high end bracket the measured number.
By their numbers in this assay, from the lowest: compound 3; then compound 4; then compound 1; then compound 2.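

In this assay, a six-membered ring can stand at this place and still give a lower number than two of the five-membered rings, with a 2.0-fold lower number from compound 1 to compound 4 (0.31 log units; beyond the scatter) and a 5.1-fold lower number from compound 2 to compound 4 (0.71 log units; beyond the scatter) when pyrimidin-4-yl enters. Even so, 1H-pyrazol-4-yl keeps the lowest number of the set, with a 7.4-fold higher number from compound 3 to compound 4 (0.87 log units; beyond the scatter) when it gives way to pyrimidin-4-yl. A hydrogen-bond donor on the ring therefore does not settle the order by itself: compound 4 has 0 hydrogen-bond donors, yet compound 2, with its 1H-pyrazol-3-yl ring, gives the higher number.

As far as these compounds go, how a pyridin-4-yl ring, or a longer chain in place of the single saturated chain carbon, would read at this place remains open. Nothing at hand explains why these rings rank as they do.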